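Working notes on two measured compounds and a third

A few compounds are considered here, and "the series" means these few. Any claim that something is new, unique, unknown or untested is made for them only; others in the source may bear on it.

Measured so far:
compound 1 `COc1ccc(Br)cc1Nc1cc(NC(=O)Nc2c(Cl)cccc2Cl)ncn1` gives 33%
compound 2 `CCc1cccc(Nc2cc(NC(=O)Nc3cc(OC)cc(OC)c3)ncn2)c1` gives 36.7%

Both numbers come from a functional assay on NCI-H226 cells (Homo sapiens) for inhibition, read by MTT assay, with a stated time of 48 h, tested at 10 uM; on this read-out lower numbers stand for less inhibition and higher numbers for more inhibition at the one concentration tested (going by the name of the read-out). Compound 2 stands highest of the two numbers shown, but its gap to compound 1 is within the scatter, so the two cannot be ordered on this read-out. Among the measured compounds shown here, no pair of measured compounds differs in only one place, so no step size is known from the data.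

Compound 3 `COc1cc(NC(=O)Nc2cc(Nc3cc(C)cc(F)c3)ncn2)cc(OC)c1` is not yet measured. It differs from compound 2 in one place: 3-fluoro-5-methylphenyl in place of 3-ethylphenyl on a nitrogen on an aromatic ring. For the measured compounds named here, the change keeps the same atom count and the same donor and acceptor count, and the two measured compounds give no step to judge such a swap by. The expectation for the step from compound 2 to compound 3 in this assay is therefore none beyond the scatter, namely a number 1.7 percentage points lower from compound 2 to compound 3 (within the scatter). For compound 3 the estimate in this assay is 35%, with a range from 20% to 52%.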

Compound 3, a percentage reported as inhibition, at one concentration (the size of the read-out at that concentration, not a potency): 35.3%
Beside the measured number, compound 3's estimate is 0.3 percentage points below it; measured number inside the range.
By their numbers in this assay, from the lowest: compounds 1, 3 and 2 (each within the scatter of the next).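

In this assay, the series gains its first one-place step, a number 1.4 percentage points lower from compound 2 to compound 3 (within the scatter), with 3-fluoro-5-methylphenyl in place of 3-ethylphenyl on a nitrogen on an aromatic ring. At this position the two groups cannot be told apart on this read-out at the one concentration tested, so this swap of equal heavy-atom count leaves the number within the scatter. Nothing measured alongside the step bears on why the two groups read alike.

Going by these compounds, whether an amine or a carboxylic acid on this phenyl ring, or a longer chain in place of the ethyl group, would move the number beyond the scatter stays open. Among the compounds shown here, compound 1 differs from compound 2 and compound 3 in more than one place, so the aryl group on the other side of the core has no step to read.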